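Alkoxy variation on the shared core: compound 3

This account rests on a few compounds, and the source may have more. Where it says the series, first, only, none or still open, it means among the compounds named here.

Measured in a functional assay on KB cells (Homo sapiens) for cytotoxicity; a higher number here means that more compound is needed for the effect, a lower number that less compound is needed:
- compound 1 `CCOc1cc(-c2ccccc2)nc2ccccc12`: 6.7 ug/mL
- compound 2 `c1ccc(COc2cc(-c3ccccc3)nc3ccccc23)cc1`: 1.6 ug/mL

Compound 2 stands at the lowest of the two numbers in this assay; its nearest neighbour is compound 1, which sits a step higher, as given by a 4.2-fold lower number from compound 1 to compound 2 (0.62 log units; beyond the scatter) read in reverse. Going by the values given here, that single step, phenyl in place of methyl on a saturated chain carbon bound to an oxygen on an aromatic ring, is the only measured step and is modest but beyond the scatter.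

Compound 3 `CC(C)Oc1cc(-c2ccccc2)nc2ccccc12` is not yet measured. It differs from compound 2 by isopropyl in place of benzyl on an oxygen on an aromatic ring. The isopropyl group of compound 3 is, like the ethyl group of compound 1, a short saturated chain without a ring, so the step from compound 1 to compound 2 bears on it in reverse: the aromatic ring that lowered the number from compound 1 to compound 2 is removed again. The number for compound 3 is therefore expected to rise back toward that of compound 1, with a step of about a 3.1-fold higher number from compound 2 to compound 3 (0.49 log units; beyond the scatter) beyond the scatter. The estimate for compound 3 in this assay is 5 ug/mL, within 2 ug/mL to 12 ug/mL.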

Compound 3, half-maximal effective concentration: 4.2 ug/mL
For compound 3 the middle estimate is 1.2-fold (0.08 log units) above the measured one, within the range that was stated.
By their numbers in this assay, from the lowest: compound 2; then compounds 3 and 1 (each within the scatter of the next).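

In this assay, the benzyl group of compound 2 now stands apart from two ring-free groups on the same oxygen rather than one, with isopropyl giving a second step of modest size (a 2.6-fold higher number from compound 2 to compound 3 (0.42 log units; beyond the scatter)) beyond the scatter. Isopropyl and ethyl, by contrast, cannot be told apart at this position: the added methyl on the saturated chain carbon gives a step (a 1.6-fold lower number from compound 1 to compound 3 (0.20 log units; within the scatter)) that lies within the scatter, so branching of this short chain has no measurable effect in these two compounds. No measurement in hand accounts for the difference between benzyl and the two ring-free groups.

With benzyl as the only ring-bearing group on this oxygen, the compounds shown do not separate the aromatic ring from the larger size of the group, a question that cyclohexylmethyl or a longer chain such as n-butyl would address. Also open, from the compounds shown here alone, is how far the benzyl result carries to a benzyl ring bearing a methoxy group or to a chain ending in an amine.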